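The compounds below may be only part of what the source reports. "The series", "measured", "known", "first", "only" and "open" are said of these compounds alone.

Compound 1 `CSc1ccc(CNc2nc(SC)nc3ncccc23)cc1`: 8750 nM
Compound 2 `CSc1ccc(CNc2nc([SeH])nc3ccccc23)cc1`: > 100000 nM, a limit
Compound 3 `CSc1nc(NCCCc2ccccc2)c2ccccc2n1`: > 100000 nM, a limit

Of the compounds shown here, three have been tested in a functional assay on HT-29 cells (Homo sapiens) for cytotoxicity, read by MTT assay, with a stated time of 72 h; on this read-out higher numbers stand for lower toxicity in this test and lower numbers for higher toxicity in this test. For the measured compounds named here, compound 1 gives 8750 nM, the only true number among the three. For compound 2 the assay reports only a limit, > 100000 nM. For compound 3 it likewise reports only a limit, > 100000 nM. Compound 1 therefore stands apart, while the other two sit at the limit of > 100000 nM in this assay, at which 2 of the 3 values shown sit.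

Compound 4 `CSc1nc(NCc2ccccc2)c2cccnc2n1` has not yet been measured. It differs from compound 1 by hydrogen in place of methylsulfanyl on an aromatic carbon, so a small group is taken away and nothing but a hydrogen atom is left in its place. Going by the values given here, no measured pair shows a change of this kind, so its size is not known from the data. The expectation is a modest step toward lower toxicity, a 2.3-fold higher number from compound 1 to compound 4 (0.36 log units; beyond the scatter). Compound 4 is thus estimated to give about 20000 nM, with a likely range from 6000 nM to 80000 nM.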

Compound 4, concentration lethal to 50% of the cells: > 100000 nM
Compound 4: no number, only a limit (the forecaster's own chance of this, stated with the estimate: 25%); middle value at least 5.0-fold (0.69 log units) from the limit.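

Taking the methylsulfanyl group off the six-membered aromatic ring of carbon only gives the first step of this kind that can be read, and it is an at least 11-fold higher number from compound 1 to compound 4 (1.05 log units; beyond the scatter). In this assay compound 4 gives > 100000 nM, which is a limit and not a number, so the step has a known minimum but no known full size. In this pair, the methylsulfanyl group para to a large group is what separates a true reading from a limit, and compound 1 is the only compound shown with a true number: the limit of > 100000 nM in this assay, at which 3 of the 4 values shown sit.

As far as these compounds go, it remains open whether the sulfur atom matters or whether any group at this place would do, which a methoxy group, a chlorine atom or a longer ethylsulfanyl chain could show. A single pair also leaves open whether the same change would have a similar effect on another core.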